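Piperazine in place of the open chain on compound 1

This account rests on a few compounds, and the source may have more. Where it says the series, first, only, none or still open, it means among the compounds named here.

Compound 1 `CN(C)CCCCCN(C)C1=Nc2ccccc2C(CC(=O)NCc2ccccc2)N1c1ccc(-c2ccccn2)cc1` has been run in a functional assay on cells (Homo sapiens) for cytotoxicity, read by MTT assay, with a stated time of 48 h (on this read-out lower numbers stand for stronger inhibition and higher numbers for weaker inhibition), and returns only a limit there. The value for compound 1, > 5000 nM, is a limit of this assay and not a number, the point recorded as the limit of > 5000 nM in this assay, at which 1 of the 2 values shown sits. Compound 2 `Cc1ccc(CNC(=O)CC2c3ccccc3N=C(N3CCN(CCN(C)C)CC3)N2c2ccc(-c3ccccc3)cc2)cc1` is the other measured member of the series; in this assay compound 2 gives 3520 nM. Going by the values given here, no step between compound 1 and compound 2 is computed, since they differ in more than one place; their two values show only that compound 2 returns a number where compound 1 returns a limit.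

Compound 3 `CN(C)CCN1CCN(C2=Nc3ccccc3C(CC(=O)NCc3ccccc3)N2c2ccc(-c3ccccn3)cc2)CC1` is not yet measured. It differs from compound 1 in one place: 4-(2-(dimethylamino)ethyl)piperazin-1-yl in place of (5-(dimethylamino)pentyl)(methyl)amino on a carbon with a double bond to nitrogen. Compound 2 carries this same entering group and gives 3520 nM, so a small gain is expected rather than none, though it may stay within the scatter. The expected step in this assay is an at least 1.2-fold lower number from compound 1 to compound 3 (0.09 log units; that floor lies within the scatter). For compound 3 the estimate in this assay is 4000 nM, with a range from 1500 nM to 15000 nM, and a fair chance that only a limit is reported again.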

Compound 3, half-maximal inhibitory concentration: > 5000 nM
Compound 3 ended at the assay's limit; the forecaster's own chance of this, stated with the estimate: 40%; middle value at least 1.2-fold (0.09 log units) from the limit.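

Going by these compounds alone, compound 1 and compound 3 both stop at a limit, not a number, so no step between them can be read: the limit of > 5000 nM in this assay, at which 2 of the 3 values shown sit.

Still open, as far as these compounds go, is whether 4-(2-(dimethylamino)ethyl)piperazin-1-yl in place of (5-(dimethylamino)pentyl)(methyl)amino changes the read-out at all, and which of the several differences from compound 1 goes with compound 2 giving 3520 nM.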